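Swapping an aryl amine for piperidine on a shared core

This account rests on a few compounds, and the source may have more. Where it says the series, first, only, none or still open, it means among the compounds named here.

- Compound 1 `Cc1ccc(NC2=CC(=O)c3nc4n(c3C2=O)[C@H]2OC[C@@H](O)[C@H]2OC4)cc1C`: 860 nM
- Compound 2 `CCCN(CCC)C1=CC(=O)c2nc3n(c2C1=O)[C@H]1OC[C@@H](O)[C@H]1OC3`: > 16000 nM, a limit of the assay and not a number
- Compound 3 `O=C1C=C(Nc2ccc(I)cc2)C(=O)c2c1nc1n2[C@H]2OC[C@@H](O)[C@H]2OC1`: 1400 nM

In a functional assay on MGC-803 cells (Homo sapiens) for inhibition, read by sulforhodamine B assay (on this read-out lower numbers stand for stronger inhibition and higher numbers for weaker inhibition), compound 3 gives 1400 nM. Its nearest neighbour is compound 1, at 860 nM, and a 1.6-fold higher number from compound 1 to compound 3 (0.21 log units; within the scatter), so these two values cannot be told apart. Compound 2 reports only a limit, > 16000 nM.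

Compound 4 `O=C1C=C(N2CCCCC2)C(=O)c2c1nc1n2[C@H]2OC[C@@H](O)[C@H]2OC1` has not been measured. It carries piperidin-1-yl in place of (4-iodophenyl)amino on a double-bonded ring carbon.

The closest evidence comes from the two measured swaps between a phenylamino group and dipropylamino. These are an at least 18-fold higher number from compound 1 to compound 2 (1.26 log units; beyond the scatter) and an at least 11-fold lower number from compound 2 to compound 3 (1.05 log units; beyond the scatter), and both are large. Piperidin-1-yl is a different group from dipropylamino, but it also replaces the phenylamino group, so a large step towards weaker inhibition in this assay is expected. The expected size is a 7.1-fold higher number from compound 3 to compound 4 (0.85 log units; beyond the scatter). The estimated value for compound 4 is 10000 nM, within an expected range of 2500 nM to 40000 nM.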

Compound 4, half-maximal inhibitory concentration: > 8000 nM
Compound 4 was reported as a limit; the forecaster's own chance of this, stated with the estimate: 45%; the middle value does not contradict the limit.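

In this assay, the earlier weakening at this double-bonded ring carbon came only from the open-chain dipropylamino, and the ring-closed piperidin-1-yl now weakens inhibition as well, with an at least 5.7-fold higher number from compound 3 to compound 4 (0.75 log units; beyond the scatter) and an at least 9.3-fold higher number from compound 1 to compound 4 (0.96 log units; beyond the scatter). Unlike the arylamino groups it replaces, piperidin-1-yl brings no aromatic ring and no hydrogen-bond donor to this carbon, and compound 4 gives a limit of the assay rather than a number: the limit of > 8000 nM in this assay, at which 1 of the 4 values shown sits.

Compound 2 also gives only a limit, so its step to compound 4 cannot be read and these two amines cannot be ranked.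

The compounds shown do not separate the absence of the aromatic ring from the absence of the amine hydrogen. Cyclohexylamino, which keeps that hydrogen without an aromatic ring, and methyl(phenyl)amino, which does the reverse, would pull these two changes apart.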